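Replacing the hydroxyphenyl end group with a nitrophenyl

This account rests on a few compounds, and the source may have more. Where it says the series, first, only, none or still open, it means among the compounds named here.

Compound 1 `COc1ccc(/C=C/C(=O)c2ccccc2NC(=O)NS(=O)(=O)c2ccc(C)cc2)cc1OC` gives 12.9 ug/mL in an ADME assay on the whole organism for cytotoxicity, with Artemia salina as the target, with a stated time of 24 h; a higher number here means that more compound is needed for the effect, a lower number that less compound is needed. Among the measured compounds shown here, compound 2 `Cc1ccc(S(=O)(=O)NC(=O)Nc2ccccc2C(=O)/C=C/c2ccccc2O)cc1` gives 32.3 ug/mL in this assay, the higher of the two numbers measured so far, and the step of a 2.5-fold higher number from compound 1 to compound 2 (0.40 log units; beyond the scatter) is the only comparison available. Compound 3 `Cc1ccc(S(=O)(=O)NC(=O)Nc2ccccc2C(=O)/C=C/c2cccc([N+](=O)[O-])c2)cc1` differs from compound 2 by 3-nitrophenyl in place of 2-hydroxyphenyl on a double-bonded chain carbon bound to a double-bonded chain carbon, a change at the same place as that earlier swap. For the measured compounds named here, since the one known step at this place was modest, a change of similar size in either direction, or none beyond the scatter, is expected, so compound 3 is estimated at 25 ug/mL in this assay, within 10 ug/mL to 60 ug/mL. That estimate means the step of a 1.3-fold lower number from compound 2 to compound 3 (0.11 log units; within the scatter) is expected.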

Compound 3, concentration for half-maximal effect: 44.5 ug/mL
Compound 3: the middle estimate sits 1.8-fold (0.25 log units) below what was measured, within the range that was stated.
By their numbers in this assay, from the lowest: compound 1; then compounds 2 and 3 (each within the scatter of the next).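

In this assay the swap gives a 1.4-fold higher number from compound 2 to compound 3 (0.14 log units; within the scatter), so exchanging 2-hydroxyphenyl, with its hydrogen-bond donor, for 3-nitrophenyl, with none, leaves the number within the scatter. Measured against 3,4-dimethoxyphenyl, the step is a 3.4-fold higher number from compound 1 to compound 3 (0.54 log units; beyond the scatter), so compound 1 now stands apart from two differently substituted phenyl groups at this place. Nothing available explains these numbers.

Open, from the compounds shown here alone, is how a phenyl group carrying an amine or a carboxylic acid, or one with a single methoxy group, would compare at this place.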